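Replacing the difluorophenyl of compound 3: expectations for compound 4

A few compounds are considered here, and "the series" means these few. Any claim that something is new, unique, unknown or untested is made for them only; others in the source may bear on it.

Three compounds have been measured in a functional assay on SW-620 cells (Homo sapiens) for antiproliferative activity, read by MTT assay, with a stated time of 72 h; a higher number here means a weaker inhibitor, a lower number a stronger inhibitor:
compound 1 `O=C1O[C@H]([C@@H](O)Cn2cc(-c3ccc(Br)cc3)nn2)C(OCc2ccccc2)=C1OCc1ccccc1`, 3760 nM;
compound 2 `CCCCCCCCCCc1cn(C[C@H](O)[C@H]2OC(=O)C(OCc3ccccc3)=C2OCc2ccccc2)nn1`, 45200 nM;
compound 3 `O=C1O[C@H]([C@@H](O)Cn2cc(-c3cc(F)cc(F)c3)nn2)C(OCc2ccccc2)=C1OCc1ccccc1`, > 100000 nM.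

The value for compound 3 is a limit of the assay, not a number. It sits at the limit of > 100000 nM in this assay, at which 1 of the 3 values shown sits, the highest point among the three. Two measured steps lead to it: an at least 26-fold higher number from compound 1 to compound 3 (1.42 log units; beyond the scatter) and an at least 2.2-fold higher number from compound 2 to compound 3 (0.34 log units; beyond the scatter), both raising the number. Compound 4 `Cc1ccc(S(=O)(=O)NCc2cn(C[C@H](O)[C@H]3OC(=O)C(OCc4ccccc4)=C3OCc3ccccc3)nn2)cc1` differs from compound 3 in one place: (((4-methylphenyl)sulfonyl)amino)methyl in place of 3,5-difluorophenyl on an aromatic carbon. Neither measured step involves a group of this kind, so they set no direction; but from a limit the number can hardly rise further, and the step expected is an at least 2.0-fold lower number from compound 3 to compound 4 (0.30 log units; that floor lies within the scatter). Compound 4 is therefore estimated at 50000 nM, between 8000 nM and 100000 nM.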

Compound 4, half-maximal inhibitory concentration: 45800 nM
Compound 4: the middle estimate sits 1.1-fold (0.04 log units) above what was measured; low and high end bracket the measured number.
By their numbers in this assay, from the lowest: compound 1; then compounds 2 and 4 (each within the scatter of the next). At a limit, above all of these: compound 3.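

Compound 3 stands at a limit of the assay, not at a number: the limit of > 100000 nM in this assay, at which 1 of the 4 values shown sits. In this assay, the (((4-methylphenyl)sulfonyl)amino)methyl group brings an at least 2.1-fold lower number from compound 3 to compound 4 (0.33 log units; beyond the scatter), so a 3,5-difluorophenyl at this aromatic carbon is not the best that can be had there. The same exchange leaves a 1.0-fold higher number from compound 2 to compound 4 (0.01 log units; within the scatter), so it does not set this group apart from decyl, while 4-bromophenyl stays ahead, with a 12-fold higher number from compound 1 to compound 4 (1.09 log units; beyond the scatter). As far as these compounds go, what remains open is whether an amine, a carboxylic acid or a simple amide on this aromatic carbon would come near compound 1.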